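This account rests on a few compounds, and the source may have more. Where it says the series, first, only, none or still open, it means among the compounds named here.

Measured so far in an assay on HEK293 cells for binding affinity to Urotensin-2 receptor (Homo sapiens), read by radioligand binding; a lower number here means a stronger inhibitor, a higher number a weaker inhibitor:
compound 1 `CN(C)CCCOc1ccc(CN2CC[C@H](NC(=O)c3ccc(C(F)(F)F)cc3)C2)cc1`, < 10000 nM, a limit of the assay rather than a number
compound 2 `CN(C)CCCOc1ccc(CN2CC[C@H](NC(=O)c3ccccc3)C2)cc1`, 2510 nM

Going by the values given here, compound 2 stands as the only genuine number in this assay; the other value shown is a limit. For compound 1 the result in this assay is a limit of the assay (the limit of < 10000 nM in this assay, at which 1 of the 2 values shown sits). Among the compounds with values here, the single step between measured compounds, a step that the limit leaves unreadable from compound 1 to compound 2, is therefore unreadable in size, and it concerns a different group from the one now in question.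

Compound 3 `CN(C)CCCOc1ccc(CN2CC[C@H](NC(=O)c3cccs3)C2)cc1` differs from compound 2 by thiophen-2-yl in place of phenyl on a carbonyl carbon. Within the data shown here, no measured step bears on this change: the one step available is unreadable and touches the trifluoromethyl, not the ring on the carbonyl carbon. The expectation for compound 3 therefore rests on compound 2 alone, at 2510 nM, with no shift expected beyond the usual scatter. The step of a 1.0-fold lower number from compound 2 to compound 3 (0.00 log units; within the scatter) is thus estimated as flat. Compound 3 is expected in this assay at 2500 nM, within a range of 800 nM to 8000 nM.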

Compound 3, inhibition constant: < 10000 nM
Compound 3: a limit, no number (the forecaster's own chance of this, stated with the estimate: 15%); the middle value is on the limit's open side.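

In this assay compound 3 gives a limit of the assay and not a number, so the new steps from compound 2 and from compound 1 to compound 3 cannot be read. The compounds shown leave open how thiophen-2-yl or 4-(trifluoromethyl)phenyl on the carbonyl carbon truly compares with the phenyl of compound 2 in this assay.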